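Working notes: from compound 3 to compound 4

The source may hold more compounds than are shown below. What is called first, only, known or untested is meant among the compounds shown, and "the series" means these compounds.

Measured so far:
compound 1 `Cc1ccc(/C=C2\CCC3=CC(=O)CCC3(C)C2=O)cc1` gives 23000 nM in a functional assay on B16 cells (Mus musculus) for inhibition, with a stated time of 3 days; a higher number here means a weaker inhibitor, a lower number a stronger inhibitor.
compound 2 `CC1CCC/C(=C\c2ccccc2)C1=O` gives > 30000 nM in this assay, a limit.
compound 3 `Cc1ccc(/C=C2\CCCC(C)C2=O)cc1` gives > 30000 nM in this assay, also a limit.

Compound 3 therefore stands at the limit of > 30000 nM in this assay, at which 2 of the 3 values shown sit; no number is known for it. Among the compounds with values here, the only one-place step among the measured compounds, a step that the two limits leave unreadable from compound 2 to compound 3, is not readable, so no measured step bears on the change to compound 4 `COc1ccc(/C=C2\CCCC(C)C2=O)cc1`, which differs from compound 3 by methoxy in place of methyl on an aromatic carbon.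

With nothing to read from, compound 4 is expected to stay near the limit of this assay, most likely reported as a limit again; the estimate for compound 4 is 30000 nM (range 10000 nM to 100000 nM). The expected step of a number no higher from compound 3 to compound 4 (the limit leaves the size open) is not one beyond the scatter.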

Compound 4, half-maximal inhibitory concentration: > 30000 nM
Compound 4 was reported as a limit (the forecaster's own chance of this, stated with the estimate: 60%); the middle value sits exactly at the limit.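

In this assay, within the data shown here, compound 4 gives the limit > 30000 nM and so no step from compound 2 or compound 3 to compound 4 can be read. Whether hydrogen, methyl or methoxy on the aromatic carbon changes inhibition stays open: the limit of > 30000 nM in this assay, at which 3 of the 4 values shown sit.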